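The source may hold more compounds than are shown below. What is called first, only, known or untested is meant among the compounds shown, and "the series" means these compounds.

Compound 1 `O=[N+]([O-])c1ccc(-c2csc(N3N=C(c4ccc(N5CCCCC5)cc4)CC3c3ccc(Cl)cc3)n2)cc1`: in a functional assay on A-375 cells (Homo sapiens) for antiproliferative activity, read by MTT assay, with a stated time of 72 h (a higher number here means a weaker inhibitor, a lower number a stronger inhibitor), compound 1 sits at the limit > 100000 nM.
Compound 2 `Clc1ccc(-c2csc(N3N=C(c4ccc(N5CCCCC5)cc4)CC3c3ccc(Cl)cc3)n2)cc1`: in this assay compound 2 likewise sits at the limit > 100000 nM.
Compound 3 `N#Cc1ccc(-c2csc(N3N=C(c4ccc(N5CCCCC5)cc4)CC3c3ccc(Cl)cc3)n2)cc1`: in this assay compound 3 gives 38700 nM.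

Among the compounds with values here, compound 3 thus holds the only number in the set; the two others stop at the limit of > 100000 nM in this assay, at which 2 of the 3 values shown sit. Compound 4 `FC(F)(F)c1ccc(-c2csc(N3N=C(c4ccc(N5CCCCC5)cc4)CC3c3ccc(Cl)cc3)n2)cc1` differs from compound 3 by trifluoromethyl in place of cyano on an aromatic carbon. Within the data shown here, no measured step involves trifluoromethyl. Among the measured compounds shown here, the steps that bear on this position are an at least 2.5-fold lower number from compound 1 to compound 3 (0.41 log units; beyond the scatter) and an at least 2.5-fold lower number from compound 2 to compound 3 (0.41 log units; beyond the scatter), both running into cyano, while a step that the two limits leave unreadable from compound 1 to compound 2. Reversing out of cyano, a higher number is expected for compound 4 in this assay, about 85000 nM with a range of 30000 nM to 300000 nM, and a fair chance of only a limit. That estimate means a step of a 2.2-fold higher number from compound 3 to compound 4 (0.34 log units; beyond the scatter).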

Compound 4, half-maximal inhibitory concentration: 64200 nM
Estimate against measurement, compound 4: 1.3-fold (0.12 log units) above; measured number inside the range.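

Trifluoromethyl is the second group at this position to give a number rather than a limit, and a 1.7-fold higher number from compound 3 to compound 4 (0.22 log units; within the scatter) leaves it unseparated from cyano. Against the other two groups, the readings are floors only: an at least 1.5-fold lower number from compound 2 to compound 4 (0.19 log units; that floor lies within the scatter) and an at least 1.5-fold lower number from compound 1 to compound 4 (0.19 log units; that floor lies within the scatter), so the true size of both gaps is unknown. Chloro and nitro remain at the limit: the limit of > 100000 nM in this assay, at which 2 of the 4 values shown sit.

Still open, from the compounds shown here alone, is whether an amine, a carboxylic acid or an amide on this aromatic carbon would shift the number beyond the scatter from compound 3.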